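The compounds below may be only part of what the source reports. "The series", "measured", "known", "first", "only" and "open" are said of these compounds alone.

In a functional assay on J774.A1 cells (Mus musculus) for inhibition, read by immunoassay, with a stated time of 12 h, tested at 30 uM (on this read-out higher numbers stand for more inhibition at the one concentration tested (going by the name of the read-out) and lower numbers for less inhibition), compound 1 `CC(C)=CCOc1ccccc1C1CC(=O)c2ccccc2O1` gives 40.3%.
In this assay compound 2 `CC(C)c1ccc(COc2ccccc2C2CC(=O)c3ccccc3O2)cc1` gives 91.7%.

For the measured compounds named here, compound 2 stands highest of the two numbers; the only other compound, compound 1, lies far below it, as the step of a number 51.4 percentage points higher from compound 1 to compound 2 (beyond the scatter) shows. Compound 3 `CCOc1ccccc1C1CC(=O)c2ccccc2O1` differs from compound 2 by methyl in place of 4-isopropylphenyl on a saturated chain carbon bound to an oxygen on an aromatic ring. Going by the values given here, the single measured step bears on this change: introducing 4-isopropylphenyl in place of 2-methylprop-1-en-1-yl raised inhibition strongly. Removing that same 4-isopropylphenyl for methyl is therefore expected to lower inhibition well beyond the scatter, because a number 51.4 percentage points higher from compound 1 to compound 2 (beyond the scatter) was large, giving an expected step of a number 61.7 percentage points lower from compound 2 to compound 3 (beyond the scatter). Compound 3 is estimated at 30%, with a range from 5% to 60%.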

Compound 3, a percentage reported as inhibition, at one concentration (the size of the read-out at that concentration, not a potency): 27.7%
Estimate against measurement, compound 3: 2.3 percentage points above, and the stated range covers the measured number.
By their numbers in this assay, from the lowest: compound 3; then compound 1; then compound 2.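

With methyl in this place, on a saturated chain carbon bound to an oxygen on an aromatic ring, the reading in this assay is a number 64 percentage points lower from compound 2 to compound 3 (beyond the scatter), so methyl gives up nearly all that 4-isopropylphenyl offered. Methyl in place of 2-methylprop-1-en-1-yl also lowers the number, with a reading a number 12.6 percentage points lower from compound 1 to compound 3 (beyond the scatter), but this is a modest step. No measurement here explains either step.

From the compounds shown here alone, it remains open whether the gain needs an aromatic ring or simply a larger group. A plain hexyl chain or an unsubstituted phenyl in this place would help separate those two readings.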